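A few compounds are considered here, and "the series" means these few. Any claim that something is new, unique, unknown or untested is made for them only; others in the source may bear on it.

The measure here is an ADME assay on BJ cells (Homo sapiens) for cytotoxicity, read by CellTiter-Glo and resazurin assay, with a stated time of 72 h; a lower number here means that less compound is needed, a higher number that more compound is needed for the effect. Compound 1 is `CC(C)N(Cc1cccc(OCCCCCC(=O)O)c1)C(=O)c1ccc(-c2ccoc2)cc1`. In this assay compound 1 gives > 26000 nM, which is a limit of the assay rather than a number. Compound 2, `CC(C)N(Cc1cccc(OCCCCCC(=O)O)c1)C(=O)c1ccc(-c2cccc(F)c2)cc1`, carries a 3-fluorophenyl in place of the furan-3-yl on an aromatic carbon. In this assay compound 2 gives > 26000 nM, again a limit and not a number. The step that the two limits leave unreadable from compound 1 to compound 2 therefore cannot be read. Within the data shown here, compound 2 thus stands where every value so far stands: the limit of > 26000 nM in this assay, at which 2 of the 2 values shown sit. Compound 3, `CC(C)N(Cc1cccc(OCCCCCC(=O)O)c1)C(=O)c1ccc(-c2cccc([N+](=O)[O-])c2)cc1`, is not yet measured; it differs from compound 2 in that (nitro in place of fluoro on an aromatic carbon). Among the measured compounds shown here, no measured step bears on this change, as both readings so far are limits and give no size. What the two compounds share is that each reaches the limit, so the step that the limit leaves unreadable from compound 2 to compound 3 is expected to be small or unreadable, leaving compound 3 at the limit as well. Compound 3 is therefore estimated at 40000 nM, with a range from 15000 nM to 150000 nM.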

Compound 3, half-maximal effective concentration: > 26000 nM
Compound 3 ended at the assay's limit; the forecaster's own chance of this, stated with the estimate: 85%; the middle value lies beyond the limit too.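

In this assay compound 3 gives > 26000 nM, a limit of the assay and not a number. No step among compound 1, compound 2 and compound 3 can be read, as all three share one reading: the limit of > 26000 nM in this assay, at which 3 of the 3 values shown sit.

Going by these compounds, what stays open is how far apart these three compounds truly lie, and whether any other group in that place would give a readable value in this assay.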